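The compounds below may be only part of what the source reports. "The series", "measured", "known", "first", "only" and "open" are said of these compounds alone.

Measured in a functional assay on HeLa cells (Homo sapiens) for antiproliferative activity, read by CCK-8 assay, with a stated time of 72 h; on this read-out lower numbers stand for stronger inhibition of growth and higher numbers for weaker inhibition of growth:
- compound 1 `CC[C@@H]1C(=O)N(C)c2cnc(-n3ccc4cc(F)ccc43)nc2N1C1CCCC1`: "not active" (no number reported)
- compound 2 `CC[C@@H]1C(=O)N(C)c2cnc(Nc3ccc(S(N)(=O)=O)cc3)nc2N1C1CCCC1`: 317 nM

In this assay compound 1 stands without a number, since it is reported only as "not active" (no number reported). Compound 2 does give a number, at 317 nM. Compound 3 `CCCNC(=O)c1ccc2c(ccn2-c2ncc3c(n2)N(C2CCCC2)[C@H](CC)C(=O)N3C)c1` keeps the core of compound 1 but has propylcarbamoyl in place of fluoro on an aromatic carbon. Within the data shown here, no measured step shows what this change does. A move towards stronger inhibition of growth is expected, of uncertain size, and compound 3 may also stay without a number. In this assay the estimate for compound 3 is an expected 1500 nM, within a range of 200 nM to 10000 nM.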

Compound 3, concentration for 50% growth inhibition: 238 nM
For compound 3 the middle estimate is 6.3-fold (0.80 log units) above the measured one; low and high end bracket the measured number.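

Among these compounds, compound 1 is reported without a number, so no step to compound 3 can be read, even though compound 3 gives 238 nM. The compounds shown leave open how much propylcarbamoyl in place of fluoro changes growth inhibition. No evidence bears on this result.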